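Urea to amide on the anilide arm of compound 2

A few compounds are considered here, and "the series" means these few. Any claim that something is new, unique, unknown or untested is made for them only; others in the source may bear on it.

Two compounds share a core and differ only at one oxygen. Compound 1 `O=C(Nc1cccc(-n2cc(-c3ccncc3)c(-c3cc(O)cc(Cl)c3)n2)c1)Nc1ccc(Cl)c(C(F)(F)F)c1` gives -52% in a functional assay on OVCAR-8 cells (Homo sapiens) for inhibition, read by sulforhodamine B assay, with a stated time of 48 h, tested at 100 uM; on this read-out higher numbers stand for a weaker effect at the one concentration tested and lower numbers for a stronger effect. Compound 2 `COc1cc(Cl)cc(-c2nn(-c3cccc(NC(=O)Nc4ccc(Cl)c(C(F)(F)F)c4)c3)cc2-c2ccncc2)c1` gives -33% in the same assay, and the change between them, methyl in place of hydrogen on an oxygen on an aromatic ring, gave a number 19 percentage points higher from compound 1 to compound 2 (beyond the scatter). Compound 2 therefore stands highest of the two numbers, the weaker of the pair at the single concentration tested.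

Compound 3 `COc1cc(Cl)cc(-c2nn(-c3cccc(NC(=O)c4cccc(C(F)(F)F)c4)c3)cc2-c2ccncc2)c1` is not yet measured. It differs from compound 2 by 3-(trifluoromethyl)phenyl in place of (4-chloro-3-(trifluoromethyl)phenyl)amino on a carbonyl carbon, so the urea becomes an amide and one hydrogen-bond donor is lost. Among the compounds with values here, no measured step touches this part of the molecule; the only step known concerns the oxygen on the other ring and says nothing about the carbonyl side. Lacking a direct precedent, the author expects compound 3 to move modestly toward a weaker effect, an expected step of a number 18 percentage points higher from compound 2 to compound 3 (beyond the scatter). His estimate for compound 3 in this assay is -15%, with a range from -55% to 30%.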

Compound 3, a percentage reported as activity, at one concentration (the size of the read-out at that concentration, not a potency): 41%
Compound 3: middle estimate off by 56 percentage points, on the low side; the whole stated range lies below it.
By their numbers in this assay, from the lowest: compound 1; then compound 2; then compound 3.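

Within the data shown here, on the carbonyl side of the molecule, which no earlier pair touched, the read-out in this assay responds strongly: the change gives a number 74 percentage points higher from compound 2 to compound 3 (beyond the scatter) and is classed as large, while the change at the oxygen on the other ring gave a number 19 percentage points higher from compound 1 to compound 2 (beyond the scatter) and was classed as modest. The sign of the read-out also flips within this pair, with compound 2 at -33% and compound 3 at 41% in the same assay, so the carbonyl substituent can reverse the direction of the number and not merely shift its size. There is no measurement here that accounts for a step of this size.

The change removes the amino nitrogen and the chlorine together, so these compounds leave open which of the two carries the step; 4-chloro-3-(trifluoromethyl)phenyl placed directly on the carbonyl carbon, or (3-(trifluoromethyl)phenyl)amino there, would separate them. Also open, going by these compounds, is whether a hydroxyl in place of the methoxy on the other ring moves the number in the same way when the amide is present, and how a carboxylic acid or a simple methyl on the carbonyl carbon would read.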